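This account rests on a few compounds, and the source may have more. Where it says the series, first, only, none or still open, it means among the compounds named here.

Compound 1 `CN1CCc2nc(C#Cc3ccccc3)sc2C1`. In an assay on HEK293 cells for negative allosteric modulation of metabotropic glutamate receptor 5 (Homo sapiens), read by FLIPR, with a stated time of 1 h (a lower number here means a stronger inhibitor, a higher number a weaker inhibitor), compound 1 gives > 10000 nM, a limit of the assay.
Compound 2 `CCCCN1CCc2nc(C#Cc3ccccc3)sc2C1`. In this assay compound 2 gives > 10000 nM, a limit.
Compound 3 `CC1CCC(C(=O)N2CCc3nc(C#Cc4ccccc4)sc3C2)CC1`. In this assay compound 3 gives > 10000 nM, a limit.

Compound 3 therefore stands at the limit of > 10000 nM in this assay, at which 3 of the 3 values shown sit, and no number is known for it. For the measured compounds named here, the only measured step, a step that the two limits leave unreadable from compound 1 to compound 2, is unreadable, since both ends are limits; it concerns a chain on an amine nitrogen in a ring and not the carbonyl carbon, so it does not bear on the change in hand.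

Compound 4 `O=C(N1CCCCC1)N1CCc2nc(C#Cc3ccccc3)sc2C1` differs from compound 3 by piperidin-1-yl in place of 4-methylcyclohexyl on a carbonyl carbon. Going by the values given here, with both neighbours of this change unmeasured beyond a limit, and the one measured step unreadable, there is no step of known size to carry over. The expectation for compound 4 is therefore a value again at or near the limit, with a step that the limit leaves unreadable from compound 3 to compound 4 that is not expected to be readable. The estimate for compound 4 in this assay is 15000 nM, within 4000 nM to 40000 nM.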

Compound 4, half-maximal inhibitory concentration: > 10000 nM
Compound 4: a limit, no number; the forecaster's own chance of this, stated with the estimate: 80%; the middle value does not contradict the limit.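

In this assay compound 4 gives > 10000 nM, a limit. Its steps from compound 1, compound 2 and compound 3 cannot be read, as both ends of each are limits. The compounds shown leave open what substituent on the shared core would give a measurable value: the limit of > 10000 nM in this assay, at which 4 of the 4 values shown sit.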